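Nitrogen substituent survey around the shared core

This account rests on a few compounds, and the source may have more. Where it says the series, first, only, none or still open, it means among the compounds named here.

Measured compounds:
compound 1 `CCNC(=O)n1cc(C(=O)c2ccn3c2CSC3c2cccnc2)c2ccc(-c3ccc(F)cc3)cc21` gives 0.18 mg/kg in a functional assay on the whole organism for inhibition, with Rattus norvegicus as the target; a higher number here means that more compound is needed for the effect, a lower number that less compound is needed
compound 2 `NC(=O)n1cc(C(=O)c2ccn3c2CSC3c2cccnc2)c2ccc(-c3ccc(F)cc3)cc21` gives 0.01 mg/kg in this assay
compound 3 `CN(C)C(=O)Cn1cc(C(=O)c2ccn3c2CSC3c2cccnc2)c2ccc(-c3ccc(F)cc3)cc21` gives 0.009 mg/kg in this assay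

Compound 3 holds the lowest number of the three, though its gap to compound 2, a 1.1-fold lower number from compound 2 to compound 3 (0.05 log units; within the scatter), lies within the scatter; only compound 1 stands apart, a 20-fold lower number from compound 1 to compound 3 (1.30 log units; beyond the scatter). Compound 4 `O=C(O)CCn1cc(C(=O)c2ccn3c2CSC3c2cccnc2)c2ccc(-c3ccc(F)cc3)cc21` differs from compound 3 by carboxymethyl in place of dimethylcarbamoyl on a saturated chain carbon bound to an aromatic nitrogen. Among the measured compounds shown here, no measured step alters this position in the same way. The step of a 1.1-fold lower number from compound 2 to compound 3 (0.05 log units; within the scatter) shows that the group on the aromatic nitrogen can vary with little effect, while an 18-fold lower number from compound 1 to compound 2 (1.26 log units; beyond the scatter) shows that an ethyl on an amide-type nitrogen there matters greatly. None of the three measured compounds carries a carboxymethyl, so the step of a 3.3-fold higher number from compound 3 to compound 4 (0.52 log units; beyond the scatter) is expected to be a modest rise held with wide uncertainty. Compound 4 is expected near 0.03 mg/kg, within 0.006 mg/kg to 0.15 mg/kg.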

Compound 4, dose for half-maximal effect: 0.1 mg/kg
Beside the measured number, compound 4's estimate is 3.3-fold (0.52 log units) below it; low and high end bracket the measured number.
By their numbers in this assay, from the lowest: compounds 3 and 2 (each within the scatter of the next); then compounds 4 and 1 (each within the scatter of the next).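

In this assay the group on the aromatic nitrogen proves less free to vary than the earlier near-equal pair suggested. Both a 10-fold higher number from compound 2 to compound 4 (1.00 log units; beyond the scatter) and an 11-fold higher number from compound 3 to compound 4 (1.05 log units; beyond the scatter) mark the 2-carboxyethyl group as a clear loss against the two best compounds. The step of a 1.8-fold lower number from compound 1 to compound 4 (0.26 log units; within the scatter) leaves it no different from ethylcarbamoyl within the scatter. Nothing available here accounts for these steps. Still open, on these data alone, is whether the loss follows the carboxylic acid itself or the chain carrying it, and whether an amine or a methyl ester on the same chain would recover the low doses.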